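The source may report more compounds than this note shows. Statements on the series, on what has been measured and on what is new or still open speak of the compounds shown alone.

Compound 3, whose structure is `CN1CCN(c2ccc(Nc3ncc(Cl)c(NCc4ccccc4)n3)nc2)CC1`, was tested in a functional assay on Jurkat cells (Homo sapiens) for inhibition, read by CCK-8 assay, with a stated time of 48 h; on this read-out lower numbers stand for stronger inhibition of growth and higher numbers for weaker inhibition of growth. There compound 3 gives only > 100000 nM, which is a limit of the assay rather than a number. Compound 3 thus stands at the limit of > 100000 nM in this assay, at which 2 of the 3 values shown sit. Of the two other compounds tested alongside it, compound 1, `Cc1ccccc1Nc1nc(Nc2cccnc2)ncc1Cl`, gives 38600 nM in this assay. Compound 2, with the structure `Cc1ccccc1Nc1nc(Nc2ccc(N3CCCCC3)cc2)ncc1Cl`, gives in this assay only > 100000 nM, again a limit of the assay. The unmeasured compound 4 has the structure `CCc1ccc(Nc2nc(Nc3ccc(N4CCN(C)CC4)cn3)ncc2Cl)cc1`. Set against compound 3, the change is 4-ethylphenyl in place of benzyl on a nitrogen on an aromatic ring. No step between two measured compounds is shown that mirrors this change, so the expected size of the step rests only on where compound 3 stands and on what compounds 1 and 2 show. Since compound 3 gives only a limit, compound 4 could at most be expected to reach a measurable number; the step from compound 3 to compound 4 is expected as an at least 1.6-fold lower number from compound 3 to compound 4 (0.22 log units; that floor lies within the scatter), with a real chance that the assay again reports only a limit. For compound 4 the estimate in this assay is 60000 nM, within a range from 15000 nM to 200000 nM.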

Compound 4, concentration for 50% growth inhibition: 11100 nM
Compound 4: the middle estimate sits 5.4-fold (0.73 log units) above what was measured; measured number below the stated range.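

In this assay, 4-ethylphenyl in place of benzyl on a nitrogen on an aromatic ring gives an at least 9.0-fold lower number from compound 3 to compound 4 (0.95 log units; beyond the scatter), a step beyond the usual scatter. This is the first pair shown that differs in one place, and it shows that the group on this nitrogen can decide whether the assay returns a measured number or only a limit. Compound 3 gives > 100000 nM, which is a limit of the assay and not a number, so the step is a floor and its full size cannot be read: the limit of > 100000 nM in this assay, at which 2 of the 4 values shown sit.

The change from benzylamino to (4-ethylphenyl)amino alters both the link between the ring and the nitrogen and the ethyl group on the ring, and the compounds shown do not separate these two parts. From the compounds shown here alone, it also stays open whether a plain phenyl without the ethyl group, or a longer chain such as propyl in its place, would give a lower or a higher number in this assay.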